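This account rests on a few compounds, and the source may have more. Where it says the series, first, only, none or still open, it means among the compounds named here.

Measured in a functional assay on MCF7 cells (Homo sapiens) for inhibition, read by MTT assay, with a stated time of 72 h; on this read-out higher numbers stand for weaker inhibition and lower numbers for stronger inhibition:
- Compound 1 `Cc1cc(Nc2cc(-c3ccccc3)[nH]n2)n2nc(SCc3ccc([N+](=O)[O-])cc3)nc2n1`: 5060 nM
- Compound 2 `Cc1cc(Nc2cc(-c3ccccc3)[nH]n2)n2nc(SCC3CCCCC3)nc2n1`: > 50000 nM, a limit of the assay, not a number
- Compound 3 `Cc1cc(Nc2cc(-c3ccccc3)[nH]n2)n2nc(SCc3ccc(Cl)cc3)nc2n1`: 8260 nM

Compound 3 has one numeric neighbour, compound 1, and lies within the scatter of it. Its other comparison is with the limit of compound 2: an at least 6.0-fold lower number from compound 2 to compound 3 (0.78 log units; beyond the scatter).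

Compound 4 `Cc1cc(Nc2cc(-c3ccccc3)[nH]n2)n2nc(SCc3nc4ccccc4[nH]3)nc2n1` has 1H-benzimidazol-2-yl in place of 4-chlorophenyl on a saturated chain carbon bound to a sulfur. Among the measured compounds shown here, two steps bear on this. Exchanging one aryl substituent for another gave a 1.6-fold higher number from compound 1 to compound 3 (0.21 log units; within the scatter), while leaving the aromatic series for cyclohexyl gave an at least 9.8-fold higher number from compound 1 to compound 2 (0.99 log units; beyond the scatter). Compound 4 keeps an aromatic group on that carbon, so the smaller step is the closer guide, though this new group has not been tested in this assay. No change beyond the scatter is expected, and the estimated result is a 1.2-fold lower number from compound 3 to compound 4 (0.07 log units; within the scatter). Compound 4 is estimated at 7000 nM, with an expected range of 2200 nM to 28000 nM.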

Compound 4, half-maximal inhibitory concentration: 2730 nM
Estimate against measurement, compound 4: 2.6-fold (0.41 log units) above, within the range that was stated.
By their numbers in this assay, from the lowest: compounds 4, 1 and 3 (each within the scatter of the next, the first and the last beyond it). At a limit, above all of these: compound 2.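

Among the aromatic groups on this saturated chain carbon bound to a sulfur, 1H-benzimidazol-2-yl brings a change beyond the scatter against 4-chlorophenyl, a 3.0-fold lower number from compound 3 to compound 4 (0.48 log units; beyond the scatter), but not against 4-nitrophenyl, a 1.9-fold lower number from compound 1 to compound 4 (0.27 log units; within the scatter). Against cyclohexyl the step is large, an at least 18-fold lower number from compound 2 to compound 4 (1.26 log units; beyond the scatter). That step starts from compound 2, which gives a limit and not a number: the limit of > 50000 nM in this assay, at which 1 of the 4 values shown sits.

The compounds shown leave open whether the hydrogen-bond donor of 1H-benzimidazol-2-yl or its added ring goes with the lower number. A 1-methyl-1H-benzimidazol-2-yl or a naphthyl group on this carbon would separate the two.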